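The source may report more compounds than this note shows. Statements on the series, on what has been measured and on what is new or still open speak of the compounds shown alone.

Compound 1 `ClCc1ccccc1Cn1cnc2c(Cl)nc(Cl)nc21` is one of three compounds examined in a functional assay on NCI-H226 cells (Homo sapiens) for cytotoxicity, read by sulforhodamine B assay, with a stated time of 48 h; a higher number here means that more compound is tolerated, a lower number that less compound is tolerated. In this assay compound 1 gives 6760 nM. Compound 2 `ClCc1cccc(Cn2cnc3c(Cl)ncnc32)c1` gives 8910 nM in this assay, a number that sits within the usual scatter of the value for compound 1. Compound 3 `ClCc1cccc(Cn2cnc3nc(Cl)nc(Cl)c32)c1` gives 20000 nM in this assay, and here the gap to compound 1 lies beyond that scatter. So compound 1 holds the smallest of the three numbers, though only compound 3 can be told apart from it with any confidence.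

Compound 4 `Nc1nc(Cl)c2ncn(Cc3ccccc3CCl)c2n1` has not yet been measured. It differs from compound 1 in one place: amino in place of chloro on an aromatic carbon. Among the measured compounds shown here, no measured pair in this set shows what such an exchange does in this assay, so the size of the step is open. The three numbers seen so far span a narrow band, and without a comparable change on record the most reasonable expectation is a modest step, if any, beyond the scatter, in the direction of a somewhat higher number. On that basis compound 4 is expected to give about 10000 nM in this assay, with a plausible range from 3500 nM to 30000 nM. That estimate implies a step of a 1.5-fold higher number from compound 1 to compound 4 (0.17 log units; within the scatter).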

Compound 4, concentration lethal to 50% of the cells: 53700 nM
The estimate for compound 4 lay 5.4-fold (0.73 log units) below the measured number, and the stated range ends below it.
By their numbers in this assay, from the lowest: compounds 1 and 2 (each within the scatter of the next); then compound 3; then compound 4.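

In this assay, amino in place of chloro on this aromatic carbon, between two ring nitrogen atoms, gives a 7.9-fold higher number from compound 1 to compound 4 (0.90 log units; beyond the scatter). Among the compounds shown here, this is the first pair in the set that differs in one place, and it shows that the number in this assay responds to an exchange at this position, since the step lies beyond the scatter. Nothing given here accounts for the size or direction of this step.

From the compounds shown here alone, with a single exchange on record, it remains open whether methoxy, methylamino or dimethylamino on the same carbon would move the number as far as amino does. Also open, going by these compounds, is whether amino would give a comparable step at this carbon on a core carrying the chloromethyl group elsewhere on the benzyl ring.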